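A carboxy group in place of the sulfanyl chain

This account rests on a few compounds, and the source may have more. Where it says the series, first, only, none or still open, it means among the compounds named here.

Measured in a functional assay (trachea) with Cavia porcellus as the target; on this read-out higher numbers stand for weaker inhibition and lower numbers for stronger inhibition:
- compound 1 `Cn1nc(-c2cccnc2)c2ccccc2c1=O`: 11500 nM
- compound 2 `O=c1c2ccccc2c(-c2cccnc2)nn1CCSc1ccccc1`: 9120 nM
- compound 3 `O=c1c2ccccc2c(-c2cccnc2)nn1CCSc1ncccn1`: 11000 nM

In this assay compound 3 gives 11000 nM, a number within the scatter of those of the other two compounds, so the three cannot be ranked.

The next compound is compound 4 `O=C(O)Cn1nc(-c2cccnc2)c2ccccc2c1=O`. It carries carboxy in place of ((pyrimidin-2-yl)sulfanyl)methyl on a saturated chain carbon bound to an aromatic nitrogen.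

Within the data shown here, three measured steps bear on this change: a 1.3-fold lower number from compound 1 to compound 2 (0.10 log units; within the scatter), a 1.0-fold lower number from compound 1 to compound 3 (0.02 log units; within the scatter) and a 1.2-fold higher number from compound 2 to compound 3 (0.08 log units; within the scatter). All three are small, and none reaches beyond the scatter, although the chain on the shared core differs in each. None of them involves a carboxy group, however, so the data give no direct measure of what this group does. The expectation in this assay is therefore no step beyond the scatter, held with wide uncertainty, and a somewhat weaker result would be no surprise.

The estimated change is a 1.2-fold higher number from compound 3 to compound 4 (0.07 log units; within the scatter). For compound 4 the expected value is 13000 nM, with an estimated range from 5000 nM to 35000 nM.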

Compound 4, half-maximal inhibitory concentration: > 100000 nM
Compound 4: no number, only a limit (the forecaster's own chance of this, stated with the estimate: 15%); middle value at least 7.6-fold (0.88 log units) from the limit.
By their numbers in this assay, from the lowest: compounds 2, 3 and 1 (each within the scatter of the next). At a limit, above all of these: compound 4.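

Up to this point, the group on the saturated chain carbon bound to an aromatic nitrogen seemed to matter little in this assay, with hydrogen, (phenylsulfanyl)methyl and ((pyrimidin-2-yl)sulfanyl)methyl all giving values within the scatter of one another. Carboxy is the first group here to take the number beyond the scatter, and it does so against all three earlier compounds: an at least 9.0-fold higher number from compound 3 to compound 4 (0.95 log units; beyond the scatter), an at least 10-fold higher number from compound 2 to compound 4 (1.04 log units; beyond the scatter) and an at least 8.6-fold higher number from compound 1 to compound 4 (0.93 log units; beyond the scatter). The step from hydrogen shows that the weaker result is tied to the arrival of carboxy and not to the loss of a sulfanyl chain, and the value of compound 4 is a limit, so these steps give only the smallest size the change can have: the limit of > 100000 nM in this assay, at which 1 of the 4 values shown sits.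

The compounds shown leave open how far the result of compound 4 lies past that limit. They also leave open whether a methyl ester or a primary amide in place of the carboxylic acid, an amine at the same place, or a longer chain ending in a carboxylic acid would bring the number back within the scatter of the first three compounds.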